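Aryl swap on the ring nitrogen: outlook for compound 4

A few compounds are considered here, and "the series" means these few. Any claim that something is new, unique, unknown or untested is made for them only; others in the source may bear on it.

Compound 3 `O=C(COCc1ccccc1)N1CCN(c2cc(Cl)ccn2)CC1` gives 570 nM in a functional assay on HEK293 cells for positive allosteric modulation of metabotropic glutamate receptor 5 (Homo sapiens), read by FLIPR and calcium flux (on this read-out lower numbers stand for an effect already at smaller amounts and higher numbers for an effect only at larger amounts of compound), and stands second highest of the three numbers, while compound 2 `O=C(COCc1ccccc1)N1CCN(c2ccc(F)cc2F)CC1` gives 300 nM and compound 1 `O=C(COCc1ccccc1)N1CCN(c2ccccc2)CC1` gives 7100 nM. The steps of a 24-fold lower number from compound 1 to compound 2 (1.37 log units; beyond the scatter) and a 12-fold lower number from compound 1 to compound 3 (1.10 log units; beyond the scatter) show that what sits on the ring nitrogen moves the read-out strongly, whereas a 1.9-fold higher number from compound 2 to compound 3 (0.28 log units; within the scatter). Compound 4 `O=C(COCc1ccccc1)N1CCN(c2ccncc2)CC1` carries pyridin-4-yl in place of 4-chloropyridin-2-yl on an amine nitrogen in a ring. Among the measured compounds shown here, no measured step covers this change directly; the closest bearing is that the bare phenyl of compound 1 gave the highest number and both substituted aryls gave a much lower read-out. A move back toward compound 1, in the upward direction, is therefore expected, a 5.3-fold higher number from compound 3 to compound 4 (0.72 log units; beyond the scatter). Compound 4 is estimated at 3000 nM, within 800 nM to 12000 nM.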

Compound 4, half-maximal effective concentration: > 25000 nM
Compound 4 gave a limit, no number; the forecaster's own chance of this, stated with the estimate: 15%; at least 8.3-fold (0.92 log units) between middle value and limit.
By their numbers in this assay, from the lowest: compounds 2 and 3 (each within the scatter of the next); then compound 1. At a limit, above all of these: compound 4.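

Compound 4 reads as a limit, not a number: the limit of > 25000 nM in this assay, at which 1 of the 4 values shown sits. A ring nitrogen in the aryl does not by itself hold the read-out low: the change gives an at least 43-fold higher number from compound 3 to compound 4 (1.64 log units; beyond the scatter), and against the fluorinated aryl it gives an at least 83-fold higher number from compound 2 to compound 4 (1.92 log units; beyond the scatter). Bare phenyl also no longer marks the top of the range, with an at least 3.5-fold higher number from compound 1 to compound 4 (0.54 log units; beyond the scatter).

The chlorine and the place of the ring nitrogen change together in this step, so their shares cannot be separated. From the compounds shown here alone, a plain pyridin-2-yl would separate them, and it remains open whether a methyl or a nitrile could stand in for the chlorine.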